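From compound 3 to compound 4: expected half-life

The source may hold more compounds than are shown below. What is called first, only, known or untested is meant among the compounds shown, and "the series" means these compounds.

Measured in an ADME assay on a cell-free system (plasma, Homo sapiens) for metabolic stability, at 37 degrees C; a lower number here means that the compound disappears faster, a higher number that the compound lasts longer:
- compound 1 `CCC/N=C1\S/C(=C\c2ccc(C(=O)OC)cc2)C(=O)N1c1ccccc1C`: > 3 h (a limit)
- compound 2 `CCC/N=C1\S/C(=C\c2ccc(C(=O)NCCO)cc2)C(=O)N1c1ccccc1C`: > 3 h (a limit)
- compound 3 `CCC/N=C1\S/C(=C\c2ccc(C(=O)O)cc2)C(=O)N1c1ccccc1O`: > 3 h (a limit)

Compound 3 has only a limit, > 3 h. The other two compounds stand no differently: the limit of > 3 h in this assay, at which 3 of the 3 values shown sit. Compound 4 `CCC/N=C1\S/C(=C\c2ccc(C(=O)OCCCO)cc2)C(=O)N1c1ccccc1O` carries this change: 3-hydroxypropyl in place of hydrogen on an oxygen next to a carbonyl group. Among the compounds with values here, the one measured step that bears on it is a step that the two limits leave unreadable from compound 1 to compound 2, which also concerns a group on a carbonyl carbon but gives no size to carry over. Compound 1, with methoxy on that carbonyl carbon, gives the limit > 3 h. On that basis, the expected change is a step that the limit leaves unreadable from compound 3 to compound 4, with no shift beyond the scatter expected in this assay. Compound 4 is estimated at 3.5 h. The expected range for compound 4 runs from 1.5 h to 8 h.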

Compound 4, half-life: > 3 h
Compound 4 was reported as a limit (the forecaster's own chance of this, stated with the estimate: 70%); the middle value does not contradict the limit.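

No step can be read from compound 3 to compound 4, as both values are limits: the limit of > 3 h in this assay, at which 4 of the 4 values shown sit. The compounds shown leave open how long any of these half-lives actually runs and whether either change alters it.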